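A few compounds are considered here, and "the series" means these few. Any claim that something is new, unique, unknown or untested is made for them only; others in the source may bear on it.

The measured compounds and their values in a functional assay for inhibition of sodium/hydrogen exchanger (Oryctolagus cuniculus); a lower number here means a stronger inhibitor, a higher number a weaker inhibitor:

compound 1, `Cc1cc(-c2cc(Cl)cc(Cl)c2)c(S(C)(=O)=O)cc1C(=O)N=C(N)N`: 130 nM
compound 2, `Cc1cc(O)c(S(C)(=O)=O)cc1C(=O)N=C(N)N`: 220 nM
compound 3, `Cc1cc(OC2CCCCC2)c(S(C)(=O)=O)cc1C(=O)N=C(N)N`: 37 nM

Compound 3 gives the lowest number of the three in this assay: its nearest neighbour is compound 1, with a 3.5-fold lower number from compound 1 to compound 3 (0.55 log units; beyond the scatter), and the furthest is compound 2, with a 5.9-fold lower number from compound 2 to compound 3 (0.77 log units; beyond the scatter). The new compound 4, `Cc1cn(-c2cc(C)c(C(=O)N=C(N)N)cc2S(C)(=O)=O)cn1`, keeps the shared core of compound 3 and differs in one place: 4-methyl-1H-imidazol-1-yl in place of cyclohexyloxy on an aromatic carbon.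

Within the data shown here, two measured steps bear on this change. The step from compound 2 to compound 3, a 5.9-fold lower number from compound 2 to compound 3 (0.77 log units; beyond the scatter), shows that filling this position with a cyclohexyl on the oxygen lowers the number substantially, and the step from compound 1 to compound 3, a 3.5-fold lower number from compound 1 to compound 3 (0.55 log units; beyond the scatter), shows that an aromatic ring at this position gives a higher number than the cyclohexyloxy. Compound 4 again carries an aromatic ring here, so a rise in the number is expected, though the ring is smaller and brings two acceptors. Compound 4 is therefore estimated at 110 nM, within 45 nM to 280 nM, meaning an expected step of a 3.0-fold higher number from compound 3 to compound 4 (0.47 log units; beyond the scatter).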

Compound 4, half-maximal inhibitory concentration: 28 nM
The estimate for compound 4 lay 3.9-fold (0.59 log units) above the measured number; the whole stated range lies above it.
By their numbers in this assay, from the lowest: compounds 4 and 3 (each within the scatter of the next); then compounds 1 and 2 (each within the scatter of the next).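

In this assay, putting 4-methyl-1H-imidazol-1-yl in place of cyclohexyloxy leaves the number within the scatter (a 1.3-fold lower number from compound 3 to compound 4 (0.12 log units; within the scatter)), so an aromatic ring on this carbon does not have to give the higher number seen with 3,5-dichlorophenyl. The same group stands clearly lower than hydroxy (a 7.9-fold lower number from compound 2 to compound 4 (0.90 log units; beyond the scatter)) and than 3,5-dichlorophenyl (a 4.6-fold lower number from compound 1 to compound 4 (0.67 log units; beyond the scatter)), which shows that a five-membered aromatic ring with 2 hetero atoms and a six-membered non-aromatic ring of carbon only can reach the same level here. Nothing at hand explains why these two different groups match. Still open, on these data alone, is how an unsubstituted imidazol-1-yl, without the methyl, would compare. As far as these compounds go, it is also open whether a morpholine or a plain amine on this aromatic carbon would stay at this level.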